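The source may hold more compounds than are shown below. What is called first, only, known or untested is meant among the compounds shown, and "the series" means these compounds.

Compound 1, `N#CC1=C(N)Oc2c(N)cc3nc4ccccc4nc3c2C12C(=O)N(Cc1cnnn1-c1cccc(Br)c1)c1ccccc12`, reaches in an ADME assay on L02 cells (Homo sapiens) for antiproliferative activity, read by MTT assay, with a stated time of 48 h (on this read-out higher numbers stand for weaker inhibition and lower numbers for stronger inhibition), only a limit: > 50000 nM.
Compound 2, `N#CC1=C(N)Oc2c(N)cc3nc4ccccc4nc3c2C12C(=O)N(Cc1cnnn1-c1ccccc1Br)c1ccccc12`, gives in this assay a number: 29200 nM.
Compound 3, `CC(=O)Nc1ccc(-n2nncc2CN2C(=O)C3(C(C#N)=C(N)Oc4c(N)cc5nc6ccccc6nc5c43)c3ccccc32)cc1`, reaches in this assay only a limit: > 50000 nM.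

The three measured compounds share one core and differ only in the group on the aromatic nitrogen of the triazole. Compound 3 stands, with compound 1, at the limit of this assay, as the limit of > 50000 nM in this assay, at which 2 of the 3 values shown sit, states, and only compound 2 has a number. The step of an at least 1.7-fold lower number from compound 1 to compound 2 (0.23 log units; that floor lies within the scatter) is small, the step of an at least 1.7-fold higher number from compound 2 to compound 3 (0.23 log units; that floor lies within the scatter) is small as well, and the step that the two limits leave unreadable from compound 1 to compound 3 cannot be read, since both of its ends are limits.

Compound 4, `COc1ccc(-n2nncc2CN2C(=O)C3(C(C#N)=C(N)Oc4c(N)cc5nc6ccccc6nc5c43)c3ccccc32)cc1`, is not yet measured. It differs from compound 3 in this: methoxy in place of acetamido on an aromatic carbon. Among the compounds with values here, none of the measured steps touches this group; the measured steps all change the aryl ring on the triazole, and the acetamido-to-methoxy exchange stands on its own. With compound 3 at the limit and compound 2 near it, compound 4 is expected to show a step of a number no higher from compound 3 to compound 4 (the limit leaves the size open), which is no step beyond the scatter. Compound 4 is therefore estimated at 50000 nM, between 15000 nM and 160000 nM, most likely reported again only as a limit.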

Compound 4, half-maximal inhibitory concentration: > 50000 nM
Compound 4: a limit, no number (the forecaster's own chance of this, stated with the estimate: 70%); the middle value sits exactly at the limit.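

For compound 4, with methoxy in place of acetamido on an aromatic carbon para to a large group, this assay again returns a limit and no number: the limit of > 50000 nM in this assay, at which 3 of the 4 values shown sit.

The steps from compound 3 to compound 4 and from compound 1 to compound 4 cannot be read, since both ends of each are limits, so this exchange shows only that neither the acetamido nor the methoxy group in this place gives a number in this assay. The one readable step is an at least 1.7-fold higher number from compound 2 to compound 4 (0.23 log units; that floor lies within the scatter), so the 4-methoxyphenyl group is not shown to separate compound 4 from compound 2, the only compound here with a number.

Going by these compounds, how far compound 1, compound 3 and compound 4 stand from one another remains open, as none of them has a number to compare. Also open, on these data alone, is whether an amine or a carboxylic acid on the same aromatic carbon, or a 2-methoxyphenyl group in place of the 2-bromophenyl group of compound 2, would give a number in this assay.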